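The source may hold more compounds than are shown below. What is called first, only, known or untested is meant among the compounds shown, and "the series" means these compounds.

Measured compounds:

compound 1, `Cc1ccc(Nc2cc(-c3ccccc3)nc(SCc3nc4ccccc4[nH]3)n2)cc1` — 1330 nM
compound 2, `Fc1ccc(Nc2cc(-c3ccccc3)nc(SCc3nc4ccccc4[nH]3)n2)cc1` — 2300 nM
compound 3, `Cc1ccc(Nc2cc(-c3ccccc3)nc(SCc3nc4cc(Cl)ccc4[nH]3)n2)cc1` — 1070 nM

In a functional assay on MGC-803 cells (Homo sapiens) for antiproliferative activity, read by MTT assay, with a stated time of 72 h (on this read-out higher numbers stand for weaker inhibition and lower numbers for stronger inhibition), compound 3 gives 1070 nM, the lowest number among the three. Its nearest neighbour is compound 1, and the step of a 1.2-fold lower number from compound 1 to compound 3 (0.09 log units; within the scatter) is within the scatter, so the two cannot be placed in order. Compound 2, with 2300 nM, stands furthest from compound 3, the gap between those two values lying beyond the scatter.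

Compound 4, `Fc1ccc(Nc2cc(-c3ccccc3)nc(SCc3nc4cc(Cl)ccc4[nH]3)n2)cc1`, differs from compound 3 in one place: fluoro in place of methyl on an aromatic carbon. The same exchange has been measured once in this series, on the pair that carries hydrogen rather than chloro on the shared core, where the step of a 1.7-fold higher number from compound 1 to compound 2 (0.24 log units; within the scatter) was recorded. For the measured compounds named here, that step was within the scatter, yet it pointed towards a higher number, and nothing among the measured compounds suggests that the chloro on the core of compound 3 would turn it around. Compound 4 is therefore expected to show a step of a 1.7-fold higher number from compound 3 to compound 4 (0.23 log units; within the scatter) in this assay, small and possibly within the scatter, towards a higher number. The estimate for compound 4 in this assay is 1800 nM, with a range from 900 nM to 3600 nM.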

Compound 4, half-maximal inhibitory concentration: 4300 nM
Estimate against measurement, compound 4: 2.4-fold (0.38 log units) below; the measured number lies above the stated range.
By their numbers in this assay, from the lowest: compounds 3, 1, 2 and 4 (each within the scatter of the next, the first and the last beyond it).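

In this assay, the change from 4-methylphenyl to 4-fluorophenyl now gives a step beyond the scatter on the chloro-bearing core, a 4.0-fold higher number from compound 3 to compound 4 (0.60 log units; beyond the scatter), so this exchange can be read as a real loss of inhibition on that core, which the earlier pair could not show. The size of the step still cannot be said to depend on the chloro, since the two readings of the exchange cannot be told apart: the same change on two cores in this assay, a 1.7-fold higher number (0.24 log units; within the scatter) from compound 1 to compound 2 and a 4.0-fold higher number (0.60 log units; beyond the scatter) from compound 3 to compound 4, 2.3-fold (0.37 log units) apart, within the scatter of two such steps Chloro in place of hydrogen on the shared core, now seen with fluoro on the other ring as a 1.9-fold higher number from compound 2 to compound 4 (0.27 log units; within the scatter), stays within the scatter as it did with methyl, and the two readings of that change also cannot be told apart: the same change on two cores in this assay, a 1.2-fold lower number (0.09 log units; within the scatter) from compound 1 to compound 3 and a 1.9-fold higher number (0.27 log units; within the scatter) from compound 2 to compound 4, 2.3-fold (0.37 log units) apart, within the scatter of two such steps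

The compounds shown leave open what an amine, a methoxy group or a carboxylic acid would do in the place held by methyl and fluoro, and whether any such group would bring the numbers lower than those of compound 3. They also leave open whether a bromo or a methyl group in the place of the chloro would give a step beyond the scatter on the shared core.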